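Ethynyl in place of 1-benzofuran-2-yl: working notes

A few compounds are considered here, and "the series" means these few. Any claim that something is new, unique, unknown or untested is made for them only; others in the source may bear on it.

Measured in a functional assay on K562 cells (Homo sapiens), read by MTT assay, with a stated time of 72 h; on this read-out higher numbers stand for weaker inhibition and lower numbers for stronger inhibition
- compound 1 (`C#Cc1cn([C@@H]2O[C@H](CO)[C@@H](O)[C@H]2O)c2ncnc(OC)c12`) gives 300 nM
- compound 2 (`CN(C)c1ncnc2c1c(-c1cc3ccccc3o1)cn2[C@@H]1O[C@H](CO)[C@@H](O)[C@H]1O`) gives > 20000 nM

Compound 2 sits at the limit of > 20000 nM in this assay, at which 1 of the 2 values shown sits, and gives a limit, not a number. Within the data shown here, the move to compound 3 (`C#Cc1cn([C@@H]2O[C@H](CO)[C@@H](O)[C@H]2O)c2ncnc(N(C)C)c12`) is ethynyl in place of 1-benzofuran-2-yl on an aromatic carbon on the shared core, and no measured step shows this change. Compound 1 also carries ethynyl and gives 300 nM in this assay. A large step toward stronger inhibition is therefore expected, estimated as an at least 13-fold lower number from compound 2 to compound 3 (1.12 log units; beyond the scatter) in this assay (an expectation only). For compound 3 the expected value is 1500 nM (estimated range 200 nM to 15000 nM).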

Compound 3, half-maximal inhibitory concentration: 110 nM
Compound 3: middle estimate off by 14-fold (1.13 log units), on the high side; measured number outside the range, below it.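

In this assay, the swap of 1-benzofuran-2-yl for ethynyl on this aromatic carbon can now be read directly: an at least 180-fold lower number from compound 2 to compound 3 (2.25 log units; beyond the scatter). Compound 2 gives a limit, not a number, so this step has no upper end: the limit of > 20000 nM in this assay, at which 1 of the 3 values shown sits. With ethynyl kept on this carbon, dimethylamino in place of methoxy on an aromatic carbon also shifts the read-out: a 2.7-fold lower number from compound 1 to compound 3 (0.44 log units; beyond the scatter). As far as these compounds go, whether a phenyl group or a longer alkyne chain on the same carbon would stay near compound 3 remains open. So does the effect of a primary amine in place of dimethylamino.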